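The source may hold more compounds than are shown below. What is called first, only, known or untested is meant among the compounds shown, and "the series" means these compounds.

Measured so far in an assay on isolated protein for inhibition of 5-hydroxytryptamine receptor 4 (Homo sapiens); on this read-out higher numbers stand for weaker inhibition and lower numbers for stronger inhibition:

compound 1 `CCCCN1CCC(CNC(=O)c2cccc3c2OCCO3)CC1`, compound 1 gives 0.794 nM
compound 2 `O=C(NCC1CCN(CCCS(=O)(=O)N2CCNCC2)CC1)c1cccc2c1OCCO2`, compound 2 gives 0.159 nM
compound 3 `CC(=O)N1CCN(S(=O)(=O)CCCN2CCC(CNC(=O)c3cccc4c3OCCO4)CC2)CC1`, compound 3 gives 0.126 nM

Compound 3 carries the lowest number of the three in this assay, yet its gap to compound 2 lies within the scatter; only compound 1 stands apart, with a higher number beyond the scatter. Compound 4 `O=C(NCC1CCN(CCCS(=O)(=O)N2CCOCC2)CC1)c1cccc2c1OCCO2` is not yet measured. It differs from compound 3 in one place: morpholin-4-yl in place of 4-acetylpiperazin-1-yl on a sulfonyl sulfur.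

For the measured compounds named here, two steps bear on it. The step of a 5.0-fold lower number from compound 1 to compound 2 (0.70 log units; beyond the scatter) shows that adding the sulfonyl-linked ring on the chain lowers the number clearly. The step of a 1.3-fold lower number from compound 2 to compound 3 (0.10 log units; within the scatter) shows that what sits on the ring nitrogen of that terminal ring barely matters. Compound 4 keeps the sulfonyl-linked six-membered ring and only exchanges the terminal ring itself, so no step beyond the scatter is expected in this assay, with the expected shift being a 1.3-fold higher number from compound 3 to compound 4 (0.10 log units; within the scatter). For compound 4 the estimate is 0.16 nM, within the range 0.06 nM to 0.45 nM.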

Compound 4, inhibition constant: 0.398 nM
Beside the measured number, compound 4's estimate is 2.5-fold (0.40 log units) below it; measured number inside the range.
By their numbers in this assay, from the lowest: compounds 3 and 2 (each within the scatter of the next); then compounds 4 and 1 (each within the scatter of the next).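

In this assay the ring on the sulfonyl sulfur does count: morpholin-4-yl in place of 4-acetylpiperazin-1-yl gives a 3.2-fold higher number from compound 3 to compound 4 (0.50 log units; beyond the scatter) and morpholin-4-yl in place of piperazin-1-yl gives a 2.5-fold higher number from compound 2 to compound 4 (0.40 log units; beyond the scatter) in a series where acetyl on the ring nitrogen had left only a 1.3-fold lower number from compound 2 to compound 3 (0.10 log units; within the scatter) as the reading. The lowering seen with the piperazine ring, a 5.0-fold lower number from compound 1 to compound 2 (0.70 log units; beyond the scatter) as the reference, does not carry over to every sulfonyl-linked ring, since the morpholine version leaves a 2.0-fold lower number from compound 1 to compound 4 (0.30 log units; within the scatter) as its step. No measurement at hand explains these steps.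

Open, on these data alone, is how piperidin-1-yl or an open-chain dimethylamino group on the sulfonyl sulfur would read against these rings. Also open, as far as these compounds go, is whether the same ring order holds on a longer chain.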